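The source may report more compounds than this note shows. Statements on the series, on what has been measured and on what is new or still open speak of the compounds shown alone.

Working notes on the series.

Compound 1 `Oc1cccc(-c2cc(-c3ccccc3)cc(-c3ccsc3)n2)c1` gives 13800 nM in a functional assay on HeLa cells (Homo sapiens) for cytotoxicity, read by ELISA, with a stated time of 2 days; a lower number here means a stronger inhibitor, a higher number a weaker inhibitor. Compound 2 `Oc1cccc(-c2cc(-c3ccccc3)cc(-c3ccco3)n2)c1` gives 9430 nM in this assay, and compound 3 `Oc1ccc(-c2cc(-c3ccccc3)cc(-c3ccsc3)n2)cc1` gives 17300 nM. Compound 4 `Oc1ccc(-c2cc(-c3ccccc3)cc(-c3ccco3)n2)cc1` has not yet been measured in this assay.

The change from compound 1 to compound 2 is furan-2-yl in place of thiophen-3-yl on an aromatic carbon and produced a 1.5-fold lower number from compound 1 to compound 2 (0.17 log units; within the scatter). The cores of compound 1 and compound 3 differ as 4-hydroxyphenyl in place of 3-hydroxyphenyl on an aromatic carbon, with a 1.3-fold higher number from compound 1 to compound 3 (0.10 log units; within the scatter). All three measured numbers therefore lie within the scatter of one another, and none of the three compounds can be ranked against the others.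

The change from compound 3 to compound 4 is furan-2-yl in place of thiophen-3-yl on an aromatic carbon. It is the same kind of change as that from compound 1 to compound 2, not the same: the place is meta to a 4-hydroxyphenyl group in compound 3, whereas in compound 1 it is meta to a 3-hydroxyphenyl group. Going by the values given here, the expectation for compound 4 is a step of about the size seen before, because a 1.5-fold lower number from compound 1 to compound 2 (0.17 log units; within the scatter) is the only precedent for this change, and it is expected that the step will be a 1.4-fold lower number from compound 3 to compound 4 (0.14 log units; within the scatter), again within the scatter. On that basis compound 4 is estimated at 12500 nM in this assay, with the likely range set from 6500 nM to 25000 nM.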

Compound 4, half-maximal inhibitory concentration: 10900 nM
Compound 4: middle estimate off by 1.1-fold (0.06 log units), on the high side, and the stated range covers the measured number.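

The exchange of thiophen-3-yl for furan-2-yl on the core of compound 3 gives a 1.6-fold lower number from compound 3 to compound 4 (0.20 log units; within the scatter) in this assay, and this agrees with the same exchange on the core of compound 1: the same change on two cores in this assay, a 1.5-fold lower number (0.17 log units; within the scatter) from compound 1 to compound 2 and a 1.6-fold lower number (0.20 log units; within the scatter) from compound 3 to compound 4, 1.1-fold (0.04 log units) apart, within the scatter of two such steps

The change from 3-hydroxyphenyl to 4-hydroxyphenyl, read on the furan-2-yl compounds, gives a 1.2-fold higher number from compound 2 to compound 4 (0.06 log units; within the scatter), and this agrees with the same change on the thiophen-3-yl compounds: the same change on two cores in this assay, a 1.3-fold higher number (0.10 log units; within the scatter) from compound 1 to compound 3 and a 1.2-fold higher number (0.06 log units; within the scatter) from compound 2 to compound 4, 1.1-fold (0.04 log units) apart, within the scatter of two such steps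

Going by these compounds alone, each change therefore carries from one core to the other without a detectable difference, but every step involved lies within the scatter, so this agreement shows only that neither change separates the compounds on either core; it does not show that either change has a real effect of constant size, and it says nothing about a change that produces a larger step.

As far as these compounds go, all four compounds share a phenyl group, a hydroxyphenyl group and a five-membered aromatic ring with 1 hetero atom, so it remains open whether any change to the shared core can give a step beyond the scatter in this assay. Also open, from the compounds shown here alone, is what would follow if an amine or a carboxylic acid stood in place of the hydroxyl group, or if a longer chain stood in place of the furan-2-yl group.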